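A few compounds are considered here, and "the series" means these few. Any claim that something is new, unique, unknown or untested is made for them only; others in the source may bear on it.

Measured in an ADME assay on CHO cells (Cricetulus griseus) for cytotoxicity, read by MTT assay, with a stated time of 24 h; a lower number here means that less compound is tolerated, a higher number that more compound is tolerated:
- compound 1 `CC1Cn2c(nc([N+](=O)[O-])c2-c2ccc(Cl)cc2)O1`: > 250000 nM (a limit)
- compound 2 `Cc1ccc(-c2c([N+](=O)[O-])nc3n2CC(C)O3)s1`: > 125000 nM (a limit)
- compound 3 `COc1cccc(C#Cc2c([N+](=O)[O-])nc3n2CC(C)O3)c1`: 12900 nM

Within the data shown here, compound 3 gives 12900 nM, the only true number in this set. The readings for compound 1 and compound 2 are both limits, so neither offers a number to set beside it.

The next compound to be tested is compound 4 `CC1Cn2c(nc([N+](=O)[O-])c2C#Cc2ccccc2)O1`, which has hydrogen in place of methoxy on an aromatic carbon of the ring that compound 3 carries: hydrogen in place of methoxy on an aromatic carbon. Of the measured compounds, only compound 3 shares the triple bond of compound 4, which makes it the sole close reference. Among the measured compounds shown here, no measured pair isolates the loss of methoxy, so the size of this step in this assay has no direct precedent.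

With compound 3 at 12900 nM as the anchor, no shift beyond the usual scatter is expected, with a slight lean towards more compound being tolerated. The expected step of a 1.4-fold higher number from compound 3 to compound 4 (0.14 log units; within the scatter) is therefore small. For compound 4 the estimated value is 18000 nM, with an expected range of 6500 nM to 55000 nM.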

Compound 4, half-maximal cytotoxic concentration: 3540 nM
Beside the measured number, compound 4's estimate is 5.1-fold (0.71 log units) above it; the whole stated range lies above it.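

Working notes on the series: in this assay, hydrogen in place of methoxy on an aromatic carbon of the six-membered aromatic ring of carbon only, meta to a large group, gives a 3.6-fold lower number from compound 3 to compound 4 (0.56 log units; beyond the scatter), so the substituent at this position has a readable bearing on the tolerated concentration in the compounds with the triple bond. Among these compounds, this pair provides the first step in the set that can be read, as it changes one place only and both compounds carry true numbers, whereas the readings for compound 1 and compound 2 are limits and offer no such comparison. The direction of the step is fixed by this single pair, with methoxy on the side of the higher number, but nothing in the data shown accounts for the change.

The compounds shown leave open whether another group at this carbon, such as a hydroxyl, an amine, a carboxylic acid or a longer alkoxy chain, would move the number in the same direction as methoxy. They also leave open whether methoxy on another carbon of this ring, or on a ring without the triple bond, would give a step of similar size.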